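The compounds below may be only part of what the source reports. "The series", "measured", "known", "first", "only" and "open" are said of these compounds alone.

Measured so far in an ADME assay on MDCK cells (Canis lupus familiaris) for cytotoxicity, read by MTT assay, with a stated time of 48 h; on this read-out lower numbers stand for higher toxicity in this test and higher numbers for lower toxicity in this test:
Compound 1 `COc1ccc([C@H]2CC(C)(O)[C@@H]3CC[C@@H](C)C[C@H]3O2)cc1` gives 689000 nM.
Compound 2 `COc1ccc([C@H]2CC(C)(O)[C@@H]3CC[C@@H](C)C[C@H]3O2)cc1OC` gives > 937000 nM, which is a limit of the assay rather than a number.
Compound 3 `COc1ccc([C@H]2CC(C)(O)[C@@H]3CC[C@@H](C)C[C@H]3O2)c(OC)c1OC` gives > 857000 nM, which is also a limit of the assay.

Compound 2 therefore stands at a limit only, and of the three values shown, two sit at limits: the limit of > 937000 nM in this assay, at which 1 of the 3 values shown sits, and (the limit of > 857000 nM in this assay, at which 1 of the 3 values shown sits). Only compound 1 gives an actual number, and it lies not far from those limits.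

Compound 4 `COc1cc([C@H]2CC(C)(O)[C@@H]3CC[C@@H](C)C[C@H]3O2)cc(OC)c1OC` differs from compound 2 by one change: methoxy in place of hydrogen on an aromatic carbon.

Among the compounds with values here, two measured steps bear on this, each being the same kind of change, a methoxy in place of hydrogen on an aromatic carbon. The first is an at least 1.3-fold higher number from compound 1 to compound 2 (0.13 log units; that floor lies within the scatter). The second is a step that the two limits leave unreadable from compound 2 to compound 3. Neither shows a readable movement beyond the scatter, and both end at a limit. Compound 4 is therefore expected to show no step beyond the scatter in this assay, and most likely another limit, so that a step that the limit leaves unreadable from compound 2 to compound 4 is the expected step.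

The value for compound 4 in this assay is estimated at 950000 nM, with a range from 500000 nM to 2000000 nM.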

Compound 4, half-maximal cytotoxic concentration: 405000 nM
For compound 4 the middle estimate is 2.3-fold (0.37 log units) above the measured one; measured number below the stated range.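

Adding a methoxy group at this aromatic carbon, ortho to a methoxy group, meta to a large group and meta to a second methoxy group, gives in this assay an at least 2.3-fold lower number from compound 2 to compound 4 (0.36 log units; beyond the scatter), and a lower number here stands for higher toxicity in this test. This is the first methoxy-for-hydrogen step among these compounds to show a movement beyond the scatter, whereas the earlier step to compound 2 has a floor within the scatter and the step to compound 3 cannot be read, so the same small change does not behave alike on every aromatic carbon. The true size of the new step may be larger than printed because compound 2 stands at a limit of the assay and not at a number: the limit of > 937000 nM in this assay, at which 1 of the 4 values shown sits.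

From the compounds shown here alone, what remains open is whether the drop belongs to the methoxy group itself or would also follow from another group on this carbon, such as a hydroxyl, a fluorine atom, an amine or a longer ethoxy chain. Also open is whether the drop needs the neighbouring methoxy groups of compound 2, since compounds with a methoxy group on this carbon alone are not among those shown.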